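The source may hold more compounds than are shown below. What is called first, only, known or untested is meant among the compounds shown, and "the series" means these compounds.

Compound 1 `CC[C@H](C)[C@H](N)CN(C(=O)[C@@H]1C[C@H]1c1ccccn1)c1ccc(-c2ccccc2)cc1` gives 130 nM in a functional assay for agonist activity at G protein-coupled receptor 88 (Homo sapiens), read by HTRF and cAMP accumulation; on this read-out higher numbers stand for an effect only at larger amounts of compound and lower numbers for an effect already at smaller amounts.
Compound 2 `COc1ccccc1-c1ccc(N(C[C@@H](N)CC(C)C)C(=O)[C@@H]2C[C@H]2c2ccccc2)cc1` gives 3200 nM in this assay.
Compound 3 `CC[C@H](C)[C@H](N)CN(C(=O)[C@@H]1C[C@H]1c1ccccc1)c1ccc(-c2ccc(C(C)(C)C)cc2)cc1` gives 750 nM in this assay.

Among these three numbers compound 3 holds the second highest. Its nearest neighbour is compound 2, which stands higher by a margin beyond the usual scatter; its furthest is compound 1, which stands lower, again beyond the scatter. Within the data shown here, no pair among the measured compounds differs in one place only, so no single step has been seen yet.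

Compound 4 `CC[C@H](C)[C@H](N)CN(C(=O)[C@@H]1C[C@H]1c1ccccc1)c1ccc(-c2ccc(COC(C)(C)C)cc2)cc1` has not been measured. It differs from compound 3 in one respect: (tert-butoxy)methyl in place of tert-butyl on an aromatic carbon. Among the measured compounds shown here, there is no measured pair showing this change, so the expectation rests on compound 3 alone and on the size of the group that enters. Compound 4 is expected to give 900 nM in this assay, with a range from 300 nM to 3000 nM. The step from compound 3 to compound 4 is therefore estimated as a 1.2-fold higher number from compound 3 to compound 4 (0.08 log units; within the scatter), likely no further than the scatter allows, with a slight lean toward a higher number.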

Compound 4, half-maximal effective concentration: 280 nM
Compound 4: middle estimate off by 3.2-fold (0.51 log units), on the high side; measured number outside the range, below it.
By their numbers in this assay, from the lowest: compound 1; then compound 4; then compound 3; then compound 2.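

Among these compounds, on the aromatic carbon para to a large group, the first single step is seen in this assay: replacing tert-butyl with (tert-butoxy)methyl gives a 2.7-fold lower number from compound 3 to compound 4 (0.43 log units; beyond the scatter), a modest change. The position therefore tolerates a larger group here, with no loss on this read-out, and the entering group also brings a hydrogen-bond acceptor that tert-butyl lacks. No measurement on hand explains the step.

This single step cannot separate the contribution of the ether oxygen from that of the longer chain; a carbon-only chain such as 3,3-dimethylbutyl, or a shorter ether such as methoxymethyl, would bear on that question. As far as these compounds go, whether the same change would give a similar step on the cores of compound 1 or compound 2 also remains open.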